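A few compounds are considered here, and "the series" means these few. Any claim that something is new, unique, unknown or untested is made for them only; others in the source may bear on it.

In a physicochemical assay for solubility, measured as kinetic solubility, at pH 7.4 (a lower number here means a less soluble compound, a higher number a more soluble compound), compound 1 (`COc1cc(N2CCNCC2)ccc1Nc1nc(NC2CCCCC2)c2nc[nH]c2n1`) gives 19000 nM and compound 2 (`COc1cc(N2CCC(CC(=O)N3CCN(C)CC3)CC2)ccc1Nc1nc(NC2CCCCC2)c2nc[nH]c2n1`) gives 38000 nM within the scatter of compound 1. Compound 3 (`COc1cc(N2CCC(CC(=O)N3CCCC3)CC2)ccc1Nc1nc(NC2CCCCC2)c2nc[nH]c2n1`) has not yet been measured. Its change from compound 2, pyrrolidin-1-yl in place of 4-methylpiperazin-1-yl on a carbonyl carbon (on a carbonyl carbon), puts pyrrolidin-1-yl in place of 4-methylpiperazin-1-yl. Going by the values given here, no measured step covers this change, so only a modest fall, hardly beyond the scatter, is expected, with a 1.7-fold lower number from compound 2 to compound 3 (0.24 log units; within the scatter) as the estimated step. Compound 3 is estimated at 22000 nM within an expected range from 8000 nM to 50000 nM on this measure.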

Compound 3, solubility: 19000 nM
Estimate against measurement, compound 3: 1.2-fold (0.06 log units) above; the range from low to high includes it.
By their numbers in this assay, from the lowest: compounds 1, 3 and 2 (each within the scatter of the next).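

In this assay, pyrrolidin-1-yl in place of 4-methylpiperazin-1-yl on a carbonyl carbon gives a 2.0-fold lower number from compound 2 to compound 3 (0.30 log units; within the scatter), so the two amides cannot be told apart on this measure. This holds even though the group that enters has 5 heavy atoms and 0 hydrogen-bond acceptors against 7 and 1 for the group that leaves. Nothing on hand accounts for this reading. From the compounds shown here alone, it remains open whether morpholin-4-yl, dimethylamino or a free carboxylic acid at this carbonyl carbon would separate from these amides. A longer chain to the carbonyl is equally unexplored here.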